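Swapping the nitro group for two chlorines on the phenyl

The source may hold more compounds than are shown below. What is called first, only, known or untested is meant among the compounds shown, and "the series" means these compounds.

For the measured compounds named here, compound 2 `O=CCN1N=C(c2ccc3ccccc3c2)CC1c1ccccc1[N+](=O)[O-]` holds the lowest of the two numbers measured so far in a functional assay on PC-3 cells (Homo sapiens) for cytotoxicity, read by sulforhodamine B assay, with a stated time of 48 h; a higher number here means a weaker inhibitor, a lower number a stronger inhibitor: compound 2 gives 3010 nM. Its nearest neighbour, compound 1 `O=CCN1N=C(c2ccc3ccccc3c2)CC1c1ccccc1`, gives 7400 nM. Going by the values given here, the one step seen, nitro replacing hydrogen, amounts to a 2.5-fold lower number from compound 1 to compound 2 (0.39 log units; beyond the scatter). Compound 3 `O=CCN1N=C(c2ccc3ccccc3c2)CC1c1cccc(Cl)c1Cl` differs from compound 2 by 2,3-dichlorophenyl in place of 2-nitrophenyl on a saturated ring carbon. Among the compounds with values here, no measured step covers chlorines on this ring, so the only guide is that a change at this position moved the number modestly. Compound 3 is expected to give roughly 2500 nM, between 900 nM and 7000 nM. That means an expected step of a 1.2-fold lower number from compound 2 to compound 3 (0.08 log units; within the scatter), likely within the scatter.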

Compound 3, half-maximal inhibitory concentration: 17900 nM
Beside the measured number, compound 3's estimate is 7.2-fold (0.85 log units) below it, and the stated range ends below it.
By their numbers in this assay, from the lowest: compound 2; then compound 1; then compound 3.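

This position can move the number in both directions: the 2,3-dichlorophenyl gives a 5.9-fold higher number from compound 2 to compound 3 (0.77 log units; beyond the scatter), and against plain phenyl it gives a 2.4-fold higher number from compound 1 to compound 3 (0.38 log units; beyond the scatter). The earlier step showed only a fall, with nitro on this ring, whereas the two chlorines take the number the opposite way. Nothing measured here accounts for that difference between the two groups.

From the compounds shown here alone, whether a single chlorine, a methoxy group or an amine on this phenyl would fall nearer compound 2 or compound 3 stays open. Going by these compounds, what the formylmethyl group contributes also stays open.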